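Sulfonyl versus difluoropropyl on the bicyclic chain

The source may hold more compounds than are shown below. What is called first, only, known or untested is meant among the compounds shown, and "the series" means these compounds.

Measured compounds:
compound 1 `Cn1c(-c2ccccc2C(F)(F)F)nnc1C12CCC(CCS(=O)(=O)C(C)(C)C)(CC1)CC2`, 10%
compound 2 `Cn1c(-c2ccccc2C(F)(F)F)nnc1C12CCC(CCCC(C)(F)F)(CC1)CC2`, 94%

In a functional assay on the whole organism (strain ICR) for inhibition, with Mus musculus as the target, with a stated time of 16 h, at a dose of 10 mg/kg by the oral route (a higher number here means more inhibition at the dose given (going by the name of the read-out), a lower number less inhibition), compound 2 stands highest of the two numbers shown; its nearest neighbour is compound 1, and the step of a number 84 percentage points higher from compound 1 to compound 2 (beyond the scatter) separates them. That single step is the only one on record, and it swaps a sulfonyl-bearing chain for a difluoroalkyl chain at the same place.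

Compound 3 `CC(C)S(=O)(=O)CCC12CCC(c3nnc(-c4ccccc4C(F)(F)F)n3C)(CC1)CC2` has not yet been measured. It differs from compound 2 by isopropylsulfonyl in place of 2,2-difluoropropyl on a saturated chain carbon, two bonds along the chain from a saturated ring carbon. The change brings a sulfonyl group back onto the chain, which is the kind of group compound 1 carries, so the step from compound 1 to compound 2 bears directly on it and runs the opposite way. A large fall in this assay is therefore expected, of about a number 69 percentage points lower from compound 2 to compound 3 (beyond the scatter). Compound 3 is estimated at 25%, within a range from 5% to 55%.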

Compound 3, a percentage reported as inhibition, in the whole organism at one dose (the size of the read-out at that dose, not a potency): 59%
Estimate against measurement, compound 3: 34 percentage points below, outside the stated range (above it).
By their numbers in this assay, from the lowest: compound 1; then compound 3; then compound 2.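

In this assay the sulfonyl chain is not uniformly poor: hydrogen in place of methyl on a saturated chain carbon bound to two saturated chain carbons and a sulfonyl sulfur gives a number 49 percentage points higher from compound 1 to compound 3 (beyond the scatter) and so shows that the group carried on the sulfonyl counts at this position. Isopropylsulfonyl in place of 2,2-difluoropropyl still gives a number 35 percentage points lower from compound 2 to compound 3 (beyond the scatter) and leaves compound 2 with the highest number of the three. Nothing on hand gives a reason for either step.

Going by these compounds, it remains open whether a methylsulfonyl chain would continue the rise seen from the tert-butyl to the isopropyl group. On these data alone, how a sulfonamide, an amine or a carboxylic acid would read at this place on the chain also remains open.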